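The source may report more compounds than this note shows. Statements on the series, on what has been measured and on what is new or still open speak of the compounds shown alone.

Working notes on the series. The read-out throughout is a functional assay on HEL cells (Homo sapiens) for cytotoxicity; a higher number here means that more compound is tolerated, a lower number that less compound is tolerated.

Compound 1 `O=C1c2ccccc2NS(=O)(=O)N1COCCO` is the parent of the first pair. In this assay compound 1 gives > 50 ug/mL, which is a limit of the assay and not a number. Compound 2 `CC(=O)OCCOCN1C(=O)c2ccccc2NS1(=O)=O` carries, relative to compound 1, the change (acetyl in place of hydrogen on an oxygen on a saturated carbon). In this assay compound 2 gives > 50 ug/mL, again only a limit. The step that the two limits leave unreadable from compound 1 to compound 2 therefore cannot be read in size from these two values.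

Compound 3 `O=C1c2ccccc2N(COCCO)S(=O)(=O)N1Cc1ccccc1` has a different core; the difference between the core of compound 1 and the core of compound 3 is not broken down here. In this assay compound 3 gives > 50 ug/mL, which is a limit. All measured values sit at one point, (the limit of > 50 ug/mL in this assay, at which 3 of the 3 values shown sit).

Compound 4 `CC(=O)OCCOCN1c2ccccc2C(=O)N(Cc2ccccc2)S1(=O)=O` is not yet measured in this assay. It differs from compound 3 by acetyl in place of hydrogen on an oxygen on a saturated carbon, the same change that leads from compound 1 to compound 2, with the place described in the same words in both cases. The expected step is a number no higher from compound 3 to compound 4 (the limit leaves the size open), an expectation that rests on a step that the two limits leave unreadable from compound 1 to compound 2 having shown no readable movement at the limit of > 50 ug/mL in this assay, at which 3 of the 3 values shown sit. For compound 4 in this assay the estimate is 50 ug/mL, with the expected range running from 25 ug/mL to 100 ug/mL, and most likely the assay will again report only a limit.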

Compound 4, minimum cytotoxic concentration: 50 ug/mL
For compound 4 middle estimate and measured number coincide at the digits printed, within the range that was stated.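

Carried onto the core of compound 3, the change from 2-hydroxyethyl to 2-acetoxyethyl gives a number no higher from compound 3 to compound 4 (the limit leaves the size open) in this assay. Compound 3 stands at > 50 ug/mL, which is a limit of the assay and not a number, and the step from compound 1 to compound 2 likewise cannot be read in size, so neither core yields a size that could be compared with the other. The pair shows only that the change gives no higher number on the second core, with compound 4 at 50 ug/mL, the one value shown that is not a limit; it does not show that the change acts equally on both cores or that it lowers the number at all, since most values sit at one point: the limit of > 50 ug/mL in this assay, at which 3 of the 4 values shown sit.

Left open is whether any other group on that oxygen would follow acetyl, for example a longer acyl chain such as hexanoyl, or whether an amine or a carboxylic acid in place of the hydroxy would move the read-out. Also open, from the compounds shown here alone, is whether the change would give a readable step on the core of compound 1, where both values shown remain limits.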